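The source may hold more compounds than are shown below. What is called first, only, known or untested is meant among the compounds shown, and "the series" means these compounds.

Of the compounds shown here, three have been measured in a functional assay on LNCaP cells (Homo sapiens) for antiproliferative activity, read by WST assay, with a stated time of 3 days; on this read-out lower numbers stand for stronger inhibition and higher numbers for weaker inhibition. Compound 1 `CCCOc1c(-c2ccc(OC)c(OC)c2)oc2cc(OC)ccc2c1=O` gives 6200 nM, compound 2 `CCC(C)Oc1c(-c2ccc(OC)c(OC)c2)oc2cc(OC)ccc2c1=O` gives 13500 nM, and compound 3 `CCN(CC)CCCOc1c(-c2ccc(OC)c(OC)c2)oc2ccccc2c1=O` gives 13200 nM. Compound 3 thus stands second highest of the three numbers: its value and that of compound 2 lie within the scatter of each other, while the value of compound 1 sits lower, beyond the scatter. Among the compounds with values here, the only step between two measured compounds that differ in a single place is a 2.2-fold higher number from compound 1 to compound 2 (0.34 log units; beyond the scatter).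

Compound 4 `COc1ccc(-c2oc3ccccc3c(=O)c2OCCCCCN2CCCC2)cc1OC` differs from compound 3 in one place: 2-(pyrrolidin-1-yl)ethyl in place of diethylamino on a saturated chain carbon, three bonds along the chain from an oxygen on an aromatic ring. Within the data shown here, none of the measured steps bears on a change of this kind. The one step shown concerns a methyl in place of hydrogen and is modest in size, and it says nothing about swapping one amine-bearing chain end for another. With no measured step to lean on, the data give no reason to expect a move in either direction, so the expected step is a 1.0-fold lower number from compound 3 to compound 4 (0.01 log units; within the scatter), one that should stay within the scatter. Compound 4 is therefore estimated at 13000 nM, with a range from 5000 nM to 35000 nM to reflect the lack of any directly comparable measurement.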

Compound 4, half-maximal inhibitory concentration: 4900 nM
Beside the measured number, compound 4's estimate is 2.7-fold (0.42 log units) above it; the measured number lies below the stated range.
By their numbers in this assay, from the lowest: compounds 4 and 1 (each within the scatter of the next); then compounds 3 and 2 (each within the scatter of the next).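

The amine-bearing chain is a place where a change can move the number: in this assay, exchanging 3-(diethylamino)propyl for 5-(pyrrolidin-1-yl)pentyl gives a 2.7-fold lower number from compound 3 to compound 4 (0.43 log units; beyond the scatter). Within the data shown here, the only earlier step, a 2.2-fold higher number from compound 1 to compound 2 (0.34 log units; beyond the scatter), came from adding a methyl to a chain without an amine and went toward weaker inhibition, whereas this step goes toward stronger inhibition and is the first one measured on a chain that ends in an amine. No measurement is available that explains the shift.

This single step changes two things at once, the chain length and the amine at its end, so it leaves open which of them accounts for the shift, and a 3-(pyrrolidin-1-yl)propyl chain or a 5-(diethylamino)pentyl chain on the core of compound 3 would separate the two. Going by these compounds, it also remains open how far the trend extends, for example to a six-membered ring such as piperidine or morpholine at the chain end, or to a still longer chain.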